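A Trifluoromethylsulfanyl Analogue Awaits Cytotoxicity Testing

The source may hold more compounds than are shown below. What is called first, only, known or untested is meant among the compounds shown, and "the series" means these compounds.

Compound 2 `Cc1ccc(NC(=O)Nc2cc(C)nc3ccccc23)cc1` was examined in an ADME assay on BJ cells (Homo sapiens) for cytotoxicity, with a stated time of 72 h; on this read-out higher numbers stand for an effect only at larger amounts of compound and lower numbers for an effect already at smaller amounts. In this assay compound 2 reaches only > 25000 nM, which is a limit of the assay rather than a number. Compound 1 `Cc1cc(NC(=O)Nc2ccc(C)c(Cl)c2)c2ccccc2n1` also gives a limit, > 25000 nM. Compound 3 `Cc1cc(NC(=O)Nc2cccnc2)c2ccccc2n1` likewise gives a limit, > 25000 nM. The step that the two limits leave unreadable from compound 1 to compound 2 and the step that the two limits leave unreadable from compound 2 to compound 3 cannot be sized, because every value sits at the limit of > 25000 nM in this assay, at which 3 of the 3 values shown sit. Compound 4 `Cc1cc(NC(=O)Nc2ccc(SC(F)(F)F)cc2)c2ccccc2n1` differs from compound 2 by (trifluoromethyl)sulfanyl in place of methyl on an aromatic carbon. Within the data shown here, no measured step with a readable size bears on this change, so neither direction nor size can be drawn from them. Compound 4 is expected to give 25000 nM, within a range from 8000 nM to 80000 nM, most likely as a limit again. This corresponds to an expected step of a number no higher from compound 2 to compound 4 (the limit leaves the size open).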

Compound 4, half-maximal effective concentration: > 25000 nM
Compound 4 was reported as a limit; the forecaster's own chance of this, stated with the estimate: 70%; the middle value lies on the limit itself.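

No step can be read from compound 2 to compound 4, because both give only a limit and no number: the limit of > 25000 nM in this assay, at which 4 of the 4 values shown sit. In this assay the compounds shown leave open at which amount, if any, an effect on the cells appears.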